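Swapping a chlorophenyl amide for an isoxazole amide

This account rests on a few compounds, and the source may have more. Where it says the series, first, only, none or still open, it means among the compounds named here.

Measured so far:
- compound 1, `O=C(Nc1ccc(Cl)c(-c2nnc3c(Cl)cccn23)c1)c1ccc(C(F)(F)F)cc1F`: 62800 nM
- compound 2, `CS(=O)(=O)c1ccc(C(=O)Nc2ccc(Cl)c(-c3nnc4c(Cl)cccn34)c2)c(Cl)c1`: > 100000 nM
- compound 3, `O=C(Nc1ccc(Cl)c(-c2nnc3c(Cl)cccn23)c1)c1cccc(Cl)c1`: 71900 nM

In a functional assay on MCF7 cells (Homo sapiens) for antiproliferative activity, read by MTT assay, with a stated time of 72 h (on this read-out lower numbers stand for stronger inhibition and higher numbers for weaker inhibition), compound 1 gives 62800 nM and compound 3 gives 71900 nM; these two values lie within the scatter of each other, so neither is set apart. For compound 2 this assay reports only a limit, > 100000 nM, which is the limit of > 100000 nM in this assay, at which 1 of the 3 values shown sits. Compound 3 thus stands with the highest of the two numbers, and all three compounds share a weak response.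

Compound 4, `O=C(Nc1ccc(Cl)c(-c2nnc3c(Cl)cccn23)c1)c1ccon1`, differs from compound 3 by 1,2-oxazol-3-yl in place of 3-chlorophenyl on a carbonyl carbon. Among the measured compounds shown here, no measured pair shows this exchange, so the direction is uncertain; the step from compound 3 to compound 4 is expected to be small, a 1.3-fold higher number from compound 3 to compound 4 (0.10 log units; within the scatter), possibly toward a weaker response. Compound 4 is estimated at 90000 nM, between 40000 nM and 200000 nM.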

Compound 4, half-maximal inhibitory concentration: > 100000 nM
Compound 4 gave a limit, no number; the forecaster's own chance of this, stated with the estimate: 45%; middle value at least 1.1-fold (0.04 log units) from the limit.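

In this assay, placing 1,2-oxazol-3-yl in place of 3-chlorophenyl on a carbonyl carbon gives an at least 1.3-fold higher number from compound 3 to compound 4 (0.14 log units; that floor lies within the scatter). Compound 4 gives only a limit, > 100000 nM, so this exchange shows no stronger response and its true size cannot be read. Compound 4 joins compound 2 at that limit: the limit of > 100000 nM in this assay, at which 2 of the 4 values shown sit.

Going by these compounds, how far compound 4 lies past its limit remains open. So does whether an aminomethyl group or a carboxylic acid on the ring at this carbonyl carbon would give a stronger response.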